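Compound 3 against the limit in the series

The source may hold more compounds than are shown below. What is called first, only, known or untested is meant among the compounds shown, and "the series" means these compounds.

Read-outs in an ADME assay on Karpas-1106P cells (Homo sapiens) for cytotoxicity; on this read-out higher numbers stand for an effect only at larger amounts of compound and lower numbers for an effect already at smaller amounts:
- compound 1 `Cc1ccc(S(=O)(=O)N[C@@H](CC(=O)NC(C)(C)C)C(=O)NCCNC(=O)c2cccc(C#N)c2)cc1`: > 11100 nM, a limit
- compound 2 `Cc1ccc(S(=O)(=O)N[C@@H](CC(=O)NC(C)(C)C)C(=O)NCCNC(=O)NCc2ccccc2)cc1`: > 11100 nM, a limit
- compound 3 `Cc1ccc(S(=O)(=O)N[C@@H](CC(=O)NC(C)(C)C)C(=O)NCCNC(=O)c2cc(C)ccc2F)cc1`: not yet measured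

Compound 2 offers no number, only the limit > 11100 nM. Going by the values given here, the series so far shows (the limit of > 11100 nM in this assay, at which 2 of the 2 values shown sit). The change now followed is 2-fluoro-5-methylphenyl in place of benzylamino on a carbonyl carbon, with 2-fluoro-5-methylphenyl in place of benzylamino on a carbonyl carbon. Among the compounds with values here, the one measured step at this place is a step that the two limits leave unreadable from compound 1 to compound 2, and it gives no size to carry over. Compound 1 and compound 2 carry different groups there, yet both read-outs are limits, so no step beyond the scatter is expected in this assay, in either direction. The expected outcome is a step that the limit leaves unreadable from compound 2 to compound 3. For compound 3 the estimate is 15000 nM, with an expected range of 8000 nM to 30000 nM. Another limit is the likeliest report.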

Compound 3, half-maximal effective concentration: > 11100 nM
Compound 3: only a limit was reported; the forecaster's own chance of this, stated with the estimate: 85%; the middle value does not contradict the limit.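

In this assay, going by these compounds alone, compound 3 gives > 11100 nM, a limit, so no step to compound 1 or compound 2 can be read. Left open is whether 3-cyanophenyl, benzylamino and 2-fluoro-5-methylphenyl on the carbonyl carbon differ at all, as the read-outs share one limit: the limit of > 11100 nM in this assay, at which 3 of the 3 values shown sit.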